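Tert-butoxycarbonyl in place of methyl: working notes

A few compounds are considered here, and "the series" means these few. Any claim that something is new, unique, unknown or untested is made for them only; others in the source may bear on it.

Measured in a functional assay on A549 cells (Homo sapiens) for antiproliferative activity, read by MTT assay, with a stated time of 48 h; on this read-out lower numbers stand for stronger inhibition and higher numbers for weaker inhibition:
Compound 1 `COc1ccc(N2CCN(Cc3ccc4c(c3O)-c3ccc(cc3O)CCc3ccc(O)c(c3)Oc3ccc(cc3)CC4)CC2)cc1`: > 20000 nM, a limit
Compound 2 `Oc1ccc2cc1Oc1ccc(cc1)CCc1ccc(CN3CCN(Cc4ccccc4)CC3)c(O)c1-c1ccc(cc1O)CC2`: > 20000 nM, a limit
Compound 3 `CN1CCN(Cc2ccc3c(c2O)-c2ccc(cc2O)CCc2ccc(O)c(c2)Oc2ccc(cc2)CC3)CC1`: 5590 nM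

Among the compounds with values here, compound 3 holds the only actual number in this assay. The other two readings stop at the limit of > 20000 nM in this assay, at which 2 of the 3 values shown sit. Compound 3 is still the most potent of the three, with an at least 3.5-fold lower number from compound 1 to compound 3 (0.55 log units; beyond the scatter) and an at least 3.5-fold lower number from compound 2 to compound 3 (0.55 log units; beyond the scatter).

Compound 4 `CC(C)(C)OC(=O)N1CCN(Cc2ccc3c(c2O)-c2ccc(cc2O)CCc2ccc(O)c(c2)Oc2ccc(cc2)CC3)CC1` is not yet measured. It differs from compound 3 by tert-butoxycarbonyl in place of methyl on an amine nitrogen in a ring.

Compounds 1 and 2 carry 4-methoxyphenyl and benzyl on that nitrogen, and neither group resembles tert-butoxycarbonyl, so they are only a loose guide. Read in reverse, an at least 3.5-fold lower number from compound 1 to compound 3 (0.55 log units; beyond the scatter) and an at least 3.5-fold lower number from compound 2 to compound 3 (0.55 log units; beyond the scatter) point to a higher number once methyl leaves. The expected change is a 3.2-fold higher number from compound 3 to compound 4 (0.51 log units; beyond the scatter), close in size to those steps, and a bare limit is quite possible. For compound 4 the estimated value is 18000 nM. The expected range for compound 4 runs from 7000 nM to 45000 nM.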

Compound 4, half-maximal inhibitory concentration: > 20000 nM
Compound 4: a limit, no number (the forecaster's own chance of this, stated with the estimate: 50%); at least 1.1-fold (0.04 log units) between middle value and limit.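

In this assay tert-butoxycarbonyl on the amine nitrogen in a ring gives an at least 3.5-fold higher number from compound 3 to compound 4 (0.55 log units; beyond the scatter) and so shows that a group with a carbonyl on this nitrogen, like 4-methoxyphenyl and benzyl, does not keep the number seen with methyl. The reading of compound 4 is a limit and not a number, and the steps among compounds 1, 2 and 4 cannot be read. Methyl is now the only group on this nitrogen with an actual number, while three different groups end at the same limit: the limit of > 20000 nM in this assay, at which 3 of the 4 values shown sit.

Going by these compounds, whether hydrogen, ethyl or acetyl on this nitrogen would give a number remains open. On these data alone, how far compound 4 lies past its limit is also open, so tert-butoxycarbonyl cannot be ranked against benzyl or 4-methoxyphenyl.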